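The source may hold more compounds than are shown below. What is called first, only, known or untested is meant among the compounds shown, and "the series" means these compounds.

Measured so far in an ADME assay on HEp-2 cells (Homo sapiens) for cytotoxicity, read by CCK-8 assay, with a stated time of 6 days; a higher number here means that more compound is tolerated, a lower number that less compound is tolerated:

Compound 1 `CCC(=O)N1CCN(c2cc(NCCN)c3ccccc3n2)CC1`: > 100000 nM
Compound 2 `NCCNc1cc(N2CCN(C(=O)C3(c4ccccc4)CC3)CC2)nc2ccccc12`: > 100000 nM
Compound 3 `NCCNc1cc(N2CCN(c3cccc(Cl)c3)CC2)nc2ccccc12`: 6400 nM

The values of compound 1 and compound 2 are limits of this assay, not numbers; (the limit of > 100000 nM in this assay, at which 2 of the 3 values shown sit). Compound 3 gives the only number shown.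

Compound 4 `NCCNc1cc(N2CCN(C(=O)CCc3ccccc3)CC2)nc2ccccc12` differs from compound 3 in one place: phenethylcarbonyl in place of 3-chlorophenyl on an amine nitrogen in a ring. Among the compounds with values here, one measured step bears on this: an at least 15-fold lower number from compound 1 to compound 3 (1.19 log units; beyond the scatter), where 3-chlorophenyl replaced propanoyl on the ring nitrogen. The change to compound 4 runs the other way, putting a carbonyl-bearing group back in place of 3-chlorophenyl. The step that the two limits leave unreadable from compound 1 to compound 2 is unreadable and adds nothing. A large rise in this assay is therefore expected, back toward the limit. Compound 4 is expected to give 60000 nM, between 20000 nM and 150000 nM. The expected step is a 9.4-fold higher number from compound 3 to compound 4 (0.97 log units; beyond the scatter).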

Compound 4, half-maximal cytotoxic concentration: > 100000 nM
Compound 4 gave a limit, no number (the forecaster's own chance of this, stated with the estimate: 50%); middle value at least 1.6-fold (0.22 log units) away from the limit.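

In this assay, the change at this ring nitrogen gives an at least 15-fold higher number from compound 3 to compound 4 (1.19 log units; beyond the scatter), now measured directly against an aromatic partner. Both groups hold a six-membered aromatic ring of carbon only, so that ring alone does not bring the number down. Compound 4 gives a limit, not a number, and the steps among compounds 1, 2 and 4 cannot be read: the limit of > 100000 nM in this assay, at which 3 of the 4 values shown sit.

Still open, going by these compounds, is whether the low number of compound 3 follows its chlorine or the missing carbonyl. A plain phenyl, or a phenethyl without the carbonyl, on this nitrogen would separate the two.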